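Amidoxime IDO1 Inhibitors: From Trifluoromethyl to Phenoxymethyl

The source may hold more compounds than are shown below. What is called first, only, known or untested is meant among the compounds shown, and "the series" means these compounds.

Compound 1: `O/N=C(/Nc1cccc(C(F)(F)F)c1)c1ccc2occc2c1`, 1200 nM
Compound 2: `O/N=C(/Nc1ccc(F)c(C(F)(F)F)c1)c1ccc2occc2c1`, 1200 nM

In an assay on isolated protein for inhibition of Indoleamine 2,3-dioxygenase 1 (Homo sapiens), read by spectrophotometry (on this read-out lower numbers stand for stronger inhibition and higher numbers for weaker inhibition), compound 1 gives 1200 nM, and compound 2 gives 1200 nM, so the two stand level within the scatter. Within the data shown here, the only measured step, no change at the digits printed from compound 1 to compound 2 (within the scatter), is a fluoro in place of hydrogen on an aromatic carbon and leaves the read-out unchanged. Compound 3, `O/N=C(/Nc1cccc(COc2ccccc2)c1)c1ccc2occc2c1`, is not yet measured; it differs from compound 1 by phenoxymethyl in place of trifluoromethyl on an aromatic carbon. Among the measured compounds shown here, no measured step resembles this exchange, since the fluoro step of compound 2 touches a different position and a far smaller group, so it offers no direct guide to direction or size. Compound 3 is therefore expected to stay near its parent, with the step of no change at the digits printed from compound 1 to compound 3 (within the scatter) estimated to lie within the scatter but with a broad uncertainty. The estimate for compound 3 in this assay is 1200 nM, ranging from 300 nM to 5000 nM.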

Compound 3, half-maximal inhibitory concentration: > 30000 nM
Compound 3 was reported as a limit; the forecaster's own chance of this, stated with the estimate: 10%; at least 25-fold (1.39 log units) between middle value and limit.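

In this assay, phenoxymethyl in place of trifluoromethyl gives an at least 25-fold higher number from compound 1 to compound 3 (1.39 log units; beyond the scatter), the first change among these compounds to move the read-out, whereas the fluoro exchange gave no change at the digits printed from compound 1 to compound 2 (within the scatter). Compound 3 reads > 30000 nM, which is a limit of the assay and not a number. Inhibition at this level therefore does not survive every exchange at this aromatic carbon, and the size of the loss is fixed only from one side: the limit of > 30000 nM in this assay, at which 1 of the 3 values shown sits.

The compounds shown leave open whether the loss goes with the added aromatic ring, the ether oxygen or the overall length of the group. A methoxy group or a plain phenyl ring at the same place would begin to separate these possibilities, and a benzyl group would test the role of the oxygen.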